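Adding Bromo to Compound 2: What to Expect

The source may report more compounds than this note shows. Statements on the series, on what has been measured and on what is new or still open speak of the compounds shown alone.

Compound 1, `CC1CCN(C2CCN(S(=O)(=O)c3cn(C)c(=O)n(C)c3=O)CC2)CC1`, is reported in an ADME assay on HCT-116 cells (Homo sapiens) for cytotoxicity, read by CellTiter-Glo, with a stated time of 72 h (a lower number here means a stronger inhibitor, a higher number a weaker inhibitor), only as a limit of the assay, not a number: > 10000 nM.
Compound 2, `CC1CCN(C2CCN(S(=O)(=O)c3cccnc3)CC2)CC1`, is likewise reported in this assay only as a limit: > 10000 nM.

Both values shown reach only the boundary of this assay rather than a number. Compound 2 therefore stands at the same boundary as compound 1, and the limit of > 10000 nM in this assay, at which 2 of the 2 values shown sit, gives the whole picture: every value shown sits there. Compound 3, `CC1CCN(C2CCN(S(=O)(=O)c3cncc(Br)c3)CC2)CC1`, is compound 2 with one change: bromo in place of hydrogen on an aromatic carbon. Among the measured compounds shown here, no step between two measured compounds exists here, so nothing shows how such a change moves the read-out in this assay. The step from compound 2 to compound 3 is expected to be small, if any, and to stay within the scatter, so compound 3 is expected at a step that the limit leaves unreadable from compound 2 to compound 3. Compound 3 is estimated to give 15000 nM, with a range from 5000 nM to 50000 nM, most likely reported again as a limit.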

Compound 3, half-maximal inhibitory concentration: > 10000 nM
Compound 3: no number, only a limit; the forecaster's own chance of this, stated with the estimate: 80%; the middle value does not contradict the limit.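

Among the compounds shown here, compound 3, like compound 2, gives only a limit and not a number, so no step between compound 2 and compound 3 can be read: the limit of > 10000 nM in this assay, at which 3 of the 3 values shown sit. The compounds shown leave open what size of effect, if any, bromo in place of hydrogen has on the read-out.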